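A few compounds are considered here, and "the series" means these few. Any claim that something is new, unique, unknown or untested is made for them only; others in the source may bear on it.

Compound 1: `COc1ccccc1C(Oc1cc(OCc2ccsc2)ccc1C#N)C(=O)O`, 529 nM
Compound 2: `Cc1ccccc1C(Oc1cc(OCc2ccccc2)ccc1C#N)C(=O)O`, 49 nM

Of the compounds shown here, two have been tested in an assay on A10 cells for antagonist activity at Endothelin-1 receptor (Rattus norvegicus); a lower number here means a stronger inhibitor, a higher number a weaker inhibitor. Compound 2 gives the lower of the two numbers, 49 nM, while compound 1 gives 529 nM; the gap between them is well beyond the usual scatter, though the two structures differ in more than one place, so no single change can be tied to it.

Compound 3, `Cc1ccccc1C(Oc1cc(OCc2ccc3ncoc3c2)ccc1C#N)C(=O)O`, has not yet been measured. It is built from compound 2 by one change: 1,3-benzoxazol-6-yl in place of phenyl on a saturated chain carbon bound to an oxygen on an aromatic ring. The shared core, the nitrile and the acid are untouched.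

Going by the values given here, with only two measured compounds and no pair that differs in one place, there is no basis for predicting a strong shift in either direction. The expectation for compound 3 is therefore a step of a 1.2-fold higher number from compound 2 to compound 3 (0.09 log units; within the scatter), which is no change beyond the scatter. Compound 3 is estimated to give 60 nM in this assay, with a likely range from 15 nM to 250 nM.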

Compound 3, half-maximal inhibitory concentration: 6 nM
Compound 3: middle estimate off by 10-fold (1.00 log units), on the high side; measured number below the stated range.
By their numbers in this assay, from the lowest: compound 3; then compound 2; then compound 1.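

Going by these compounds alone, compound 2 and compound 3 form the first pair that differs in one place, so in this assay one change can now be read on its own: 1,3-benzoxazol-6-yl in place of phenyl gives an 8.2-fold lower number from compound 2 to compound 3 (0.91 log units; beyond the scatter) and lies beyond the usual scatter. This position, a saturated chain carbon bound to an oxygen on an aromatic ring, therefore accepts a group with more heavy atoms and a second ring, and the number falls rather than rises. No measurement shown accounts for this step.

On these data alone, it remains open whether the gain needs the nitrogen and oxygen of the benzoxazole or only its second ring, a question that a naphthyl group, built of carbon alone, could help to settle. As far as these compounds go, whether the same change would give a similar step with other groups elsewhere on the shared core also stays open.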